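The source may report more compounds than this note shows. Statements on the series, on what has been measured and on what is new or still open speak of the compounds shown alone.

Compound 1 `Nc1nc(N)c2cc(CSC(=S)N3CCN(c4ccccc4Cl)CC3)ccc2n1`: 5490 nM
Compound 2 `Nc1nc(N)c2cc(CSC(=S)N3CCN(c4ccc([N+](=O)[O-])cc4)CC3)ccc2n1`: 4680 nM

In a functional assay on HCT-116 cells (Homo sapiens) for antiproliferative activity, read by MTT assay, with a stated time of 72 h (a lower number here means a stronger inhibitor, a higher number a weaker inhibitor), compound 2 stands level with compound 1. Among the compounds with values here, the only measured step is a 1.2-fold lower number from compound 1 to compound 2 (0.07 log units; within the scatter). Compound 3 `Nc1nc(N)c2cc(CSC(=S)N3CCN(c4ccccn4)CC3)ccc2n1` has not yet been measured. It carries pyridin-2-yl in place of 4-nitrophenyl on an amine nitrogen in a ring. The measured step changed the group at that same place and stayed within the scatter, so no step beyond the scatter is expected here, in either direction. For compound 3 the estimated value is 5000 nM, with an expected range from 2000 nM to 12000 nM. This estimate means an expected 1.1-fold higher number from compound 2 to compound 3 (0.03 log units; within the scatter).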

Compound 3, half-maximal inhibitory concentration: 5960 nM
Compound 3: the middle estimate sits 1.2-fold (0.08 log units) below what was measured, within the range that was stated.
By their numbers in this assay, from the lowest: compounds 2, 1 and 3 (each within the scatter of the next).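

In this assay, the step of a 1.3-fold higher number from compound 2 to compound 3 (0.11 log units; within the scatter) and the step of a 1.1-fold higher number from compound 1 to compound 3 (0.04 log units; within the scatter) both stay within the scatter. On this amine nitrogen, then, a six-membered aromatic ring with a hetero atom reads level with the two substituted phenyl groups, so three different aromatic groups at this place have produced no step beyond the scatter. No evidence here explains this.
Still open, as far as these compounds go, is whether a non-aromatic group at this nitrogen, such as a benzyl group, a longer alkyl chain or a chain ending in a carboxylic acid, would give a number beyond the scatter.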